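Cyclopentyl in Place of Benzyl on a Shared Core

This account rests on a few compounds, and the source may have more. Where it says the series, first, only, none or still open, it means among the compounds named here.

Compound 2 `O=C1C=C(NCc2ccccc2)C(=O)c2c1nc1n2[C@H]2OC[C@@H](O)[C@H]2OC1` carries a benzylamino group on the shared core. In a functional assay on MCF7 cells (Homo sapiens) for inhibition, read by sulforhodamine B assay (on this read-out higher numbers stand for weaker inhibition and lower numbers for stronger inhibition), compound 2 gives > 8000 nM, which is a limit of the assay and not a number. Compound 1 `O=C1C(N2CCCCC2)=CC(=O)c2c1nc1n2[C@H]2OC[C@@H](O)[C@H]2OC1` gives > 8000 nM in this assay, also a limit. Compound 3 `O=C1C(NC2CCCC2)=CC(=O)c2c1nc1n2[C@H]2OC[C@@H](O)[C@H]2OC1` gives > 16000 nM in this assay, again a limit. Among the compounds with values here, the one measured step toward a cyclopentylamino group, a step that the two limits leave unreadable from compound 1 to compound 3, is therefore unreadable, sitting between the limit of > 8000 nM in this assay, at which 2 of the 3 values shown sit, and (the limit of > 16000 nM in this assay, at which 1 of the 3 values shown sits).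

Compound 4 `O=C1C=C(NC2CCCC2)C(=O)c2c1nc1n2[C@H]2OC[C@@H](O)[C@H]2OC1` has not been measured. It differs from compound 2 by cyclopentyl in place of benzyl on an amine nitrogen. Within the data shown here, no measured step bears directly on this exchange, and every value shown sits at a limit, so nothing among the three compounds points to a readable change in either direction. The step that the limit leaves unreadable from compound 2 to compound 4 is accordingly expected to stay hidden beneath the limit. Compound 4 is expected to give 20000 nM, within a range from 8000 nM to 60000 nM, most likely reported only as a limit.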

Compound 4, half-maximal inhibitory concentration: > 16000 nM
Compound 4 was reported as a limit; the forecaster's own chance of this, stated with the estimate: 85%; the middle value is on the limit's open side.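

Compound 2 and compound 4 both stand at limits of the assay and not at numbers, so the exchange of benzylamino for cyclopentylamino between them cannot be read. The compounds shown leave open where the true potency of any of them lies in this assay.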